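Fluoro to tert-butyl on compound 2

This account rests on a few compounds, and the source may have more. Where it says the series, first, only, none or still open, it means among the compounds named here.

In a functional assay on cells for positive allosteric modulation, with A2780/Taxol (Homo sapiens) as the target, read by MTT assay, with a stated time of 48 h, tested at 10 uM (on this read-out higher numbers stand for weaker inhibition and lower numbers for stronger inhibition), compound 1 `CCOc1ccc2c(C)cc(=O)oc2c1COC(=O)c1ccc(F)cc1` gives 64.7 nM and compound 2 `Cc1cc(=O)oc2c(COC(=O)c3ccc(F)cc3)c(OC(C)C)ccc12` gives 42.9 nM. Going by the values given here, the only measured step, a 1.5-fold lower number from compound 1 to compound 2 (0.18 log units; within the scatter), leaves compound 2 within the scatter of compound 1. That step concerns a different group, so no measurement covers the change to compound 3 `Cc1cc(=O)oc2c(COC(=O)c3ccc(C(C)(C)C)cc3)c(OC(C)C)ccc12`: tert-butyl in place of fluoro on an aromatic carbon, with tert-butyl in place of fluoro on an aromatic carbon, para to a large group. With no measured guide, the expected step is a 1.4-fold higher number from compound 2 to compound 3 (0.15 log units; within the scatter), which is nothing beyond the scatter. The estimated value for compound 3 is 60 nM, with an expected range of 15 nM to 240 nM.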

Compound 3, half-maximal inhibitory concentration: 55.5 nM
Beside the measured number, compound 3's estimate is 1.1-fold (0.03 log units) above it; the measured number falls inside the stated range.
By their numbers in this assay, from the lowest: compounds 2, 3 and 1 (each within the scatter of the next).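

In this assay the change from 4-fluorophenyl to 4-(tert-butyl)phenyl gives a 1.3-fold higher number from compound 2 to compound 3 (0.11 log units; within the scatter) and is the only measured change at this position among the compounds shown. On an aromatic carbon para to a large group, four carbon atoms in place of one fluorine therefore leave the number within the scatter. Nothing at hand bears on why. Open, on these data alone, is whether a different group at this place, such as an amine or a carboxylic acid, would shift the number beyond the scatter.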